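Adding a Trifluoromethyl Group to the Benzylsulfanyl Ring

The source may report more compounds than this note shows. Statements on the series, on what has been measured and on what is new or still open speak of the compounds shown alone.

Of the compounds shown here, three sharing one core have been measured in an ADME assay on microsomes from liver (Homo sapiens) for metabolic stability, read by LC-MS, using NADPH, tested at 5 uM; on this read-out higher numbers stand for a longer-lived compound and lower numbers for a shorter-lived compound. Compound 1 `Cc1cc(-c2ccccc2)n(/C(N)=N/S(=O)(=O)c2cc(C)c(Cl)cc2SCc2ccccc2Cl)n1` gives 0.163 h. Compound 2 `Cc1cccc(CSc2cc(Cl)c(C)cc2S(=O)(=O)/N=C(\N)n2nc(C)cc2-c2ccccc2)c1` gives 0.214 h. Compound 3 `Cc1cc(-c2ccccc2)n(/C(N)=N/S(=O)(=O)c2cc(C)c(Cl)cc2SCc2ccccc2)n1` gives 0.0938 h, the lowest of the three numbers; the gap to compound 1 is within the scatter, while the gap to compound 2, a 2.3-fold lower number from compound 2 to compound 3 (0.36 log units; beyond the scatter), is modest but beyond it.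

Compound 4 `Cc1cc(-c2ccccc2)n(/C(N)=N/S(=O)(=O)c2cc(C)c(Cl)cc2SCc2cccc(C(F)(F)F)c2)n1` differs from compound 3 in one place: trifluoromethyl in place of hydrogen on an aromatic carbon. Among the measured compounds shown here, no measured step introduces a trifluoromethyl group, so the closest guides are the steps that add or remove other groups on the same ring. From compound 1 to compound 3 the step was a 1.7-fold lower number from compound 1 to compound 3 (0.24 log units; within the scatter), from compound 2 to compound 3 it was a 2.3-fold lower number from compound 2 to compound 3 (0.36 log units; beyond the scatter), and from compound 1 to compound 2 it was a 1.3-fold higher number from compound 1 to compound 2 (0.12 log units; within the scatter). A substituent on this ring has so far gone with a somewhat higher number, so a small rise is expected in this assay, a 1.8-fold higher number from compound 3 to compound 4 (0.26 log units; within the scatter). Compound 4 is therefore estimated at 0.17 h, within a range of 0.08 h to 0.35 h.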

Compound 4, half-life: 0.169 h
Compound 4: middle estimate off by 1.0-fold (0.00 log units), on the high side; low and high end bracket the measured number.
By their numbers in this assay, from the lowest: compounds 3, 1, 4 and 2 (each within the scatter of the next, the first and the last beyond it).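

In this assay trifluoromethyl in place of hydrogen on this aromatic carbon cannot be told apart from hydrogen (a 1.8-fold higher number from compound 3 to compound 4 (0.26 log units; within the scatter)). Trifluoromethyl in place of methyl also stays inside the scatter (a 1.3-fold lower number from compound 2 to compound 4 (0.10 log units; within the scatter)), as does 3-(trifluoromethyl)phenyl in place of 2-chlorophenyl (a 1.0-fold higher number from compound 1 to compound 4 (0.02 log units; within the scatter)), so compound 4 lies within the scatter of all three earlier compounds, although compound 2 and compound 3 lie beyond the scatter of each other. No measurement shown here accounts for these numbers.

Still open, going by these compounds, is whether a quite different group on this ring, such as an amine or a carboxylic acid, would move the half-life beyond the scatter from compound 3. Also open, on these data alone, is how trifluoromethyl would behave on another carbon of this ring.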